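A Bicyclic Diamine Replaces the Piperazine on the Core

A few compounds are considered here, and "the series" means these few. Any claim that something is new, unique, unknown or untested is made for them only; others in the source may bear on it.

Compound 1 `C[C@@H]1CN(c2cccc3c2C[C@H](CN(C)[C@H]2CCCc4cccnc42)NC3)C[C@H](C)N1` gives 61 nM in a functional assay on CCRF-CEM cells for antagonist activity at C-X-C chemokine receptor type 4 (Homo sapiens), read by calcium flux, with stated times of 25 min and 90 s; a higher number here means a weaker inhibitor, a lower number a stronger inhibitor.
Compound 2 `CC(C)N1CCN(c2cccc3c2C[C@H](CN(C)[C@H]2CCCc4cccnc42)NC3)CC1` gives 16.9 nM in this assay.
Compound 3 `CCN1CCN(c2cccc3c2C[C@H](CN(C)[C@H]2CCCc4cccnc42)NC3)CC1` gives 13.8 nM in this assay.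

Compound 3 has the lowest number of the three, but its gap to compound 2 is small: a 1.2-fold lower number from compound 2 to compound 3 (0.09 log units; within the scatter). Compound 4 `CN(C[C@H]1Cc2c(cccc2N2C[C@H]3C[C@@H]2CN3)CN1)[C@H]1CCCc2cccnc21` differs from compound 3 in that (a group of 7 heavy atoms (5 carbon, 2 nitrogen; 2 five-membered non-aromatic rings with 1 hetero atom each) in place of a group of 8 heavy atoms (6 carbon, 2 nitrogen; one six-membered non-aromatic ring with 2 hetero atoms), on an aromatic carbon). Going by the values given here, the steps that bear on this are a 3.6-fold lower number from compound 1 to compound 2 (0.56 log units; beyond the scatter) and a 4.4-fold lower number from compound 1 to compound 3 (0.65 log units; beyond the scatter), where the group with a hydrogen-bond donor was the weaker one. The entering group of compound 4 likewise brings a hydrogen-bond donor, so a modestly weaker result is expected. Compound 4 is therefore estimated at 40 nM, with a range of 15 nM to 120 nM. The expected step is a 2.9-fold higher number from compound 3 to compound 4 (0.46 log units; beyond the scatter).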

Compound 4, half-maximal inhibitory concentration: 20.7 nM
Compound 4: the middle estimate sits 1.9-fold (0.29 log units) above what was measured; low and high end bracket the measured number.
By their numbers in this assay, from the lowest: compounds 3, 2 and 4 (each within the scatter of the next); then compound 1.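

At this aromatic carbon, the bridged group with its hydrogen-bond donor stays within the scatter of both alkylated piperazines in this assay (a 1.5-fold higher number from compound 3 to compound 4 (0.18 log units; within the scatter); a 1.2-fold higher number from compound 2 to compound 4 (0.09 log units; within the scatter)). It nevertheless separates from 3,5-dimethylpiperazin-1-yl, which also carries a donor (a 2.9-fold lower number from compound 1 to compound 4 (0.47 log units; beyond the scatter)), so the presence of a donor does not by itself set the number across these compounds. Nothing shown here explains this difference between the two donor-bearing groups.

The compounds shown leave open how the bridged group would read with an ethyl group on its ring nitrogen, as in the 4-ethylpiperazin-1-yl of compound 3. They also leave open how a morpholin-4-yl group would compare at the same carbon.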